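From Hydroxy to Dimethylamino on a Shared Core

This account rests on a few compounds, and the source may have more. Where it says the series, first, only, none or still open, it means among the compounds named here.

Measured compounds:
- compound 1, `COc1ccc(/C=N\NC(=S)NC(C)(C)CCC[C@](C)(O)[C@@H]2CC=C(C)CC2)cc1`; in a functional assay on MCF7 cells (Homo sapiens) for cytotoxicity, read by sulforhodamine B assay (a higher number here means that more compound is tolerated, a lower number that less compound is tolerated), compound 1 gives > 100000 nM, which is a limit of the assay and not a number.
- compound 2, `CC1=CC[C@@H]([C@@](C)(O)CCCC(C)(C)NC(=S)N/N=C\c2ccc(O)cc2)CC1`; in this assay compound 2 gives 56400 nM.

Compound 2 holds the only actual number shown in this assay. The value of compound 1 is a limit. For the measured compounds named here, the single measured step, an at least 1.7-fold lower number from compound 1 to compound 2 (0.24 log units; that floor lies within the scatter), removes a methyl from an oxygen and does not match the change leading to compound 3, `CC1=CC[C@@H]([C@@](C)(O)CCCC(C)(C)NC(=S)N/N=C\c2ccc(N(C)C)cc2)CC1`: dimethylamino in place of hydroxy on an aromatic carbon. Going by the values given here, no measured step therefore bears on this change, and the expected step is a 1.4-fold lower number from compound 2 to compound 3 (0.15 log units; within the scatter), within the usual scatter. For compound 3 the estimated value in this assay is 40000 nM, ranging from 10000 nM to 150000 nM.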

Compound 3, concentration lethal to 50% of the cells: > 100000 nM
Compound 3 was reported as a limit; the forecaster's own chance of this, stated with the estimate: 25%; middle value at least 2.5-fold (0.39 log units) away from the limit.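

In this assay compound 3 gives > 100000 nM, which is a limit of the assay and not a number. Dimethylamino in place of hydroxy at this position gives an at least 1.7-fold higher number from compound 2 to compound 3 (0.24 log units; that floor lies within the scatter), so a real change is not established, and hydroxy remains the only group here with an actual number. The step involving the two limits cannot be read, and the assay offers little room at this end: the limit of > 100000 nM in this assay, at which 2 of the 3 values shown sit.

Going by these compounds, how far the true value of compound 3 lies past that limit stays open. So does what a primary amine or a carboxylic acid at this position would give.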